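The source may hold more compounds than are shown below. What is called first, only, known or untested is meant among the compounds shown, and "the series" means these compounds.

Working notes on the series.

The three measured compounds share one core and differ at two places. In a functional assay on C6 cells (Rattus norvegicus) for cytotoxicity, read by MTT assay, with a stated time of 24 h, tested at 200 ug/mL (on this read-out lower numbers stand for a stronger effect and higher numbers for a weaker effect at the one concentration tested), compound 1 `Cc1ccc(-c2cs/c(=N/NC(=O)CSc3nncn3C)n2-c2ccccc2)cc1` gives 27.8%, compound 2 `O=C(CSc1nnnn1-c1ccccc1)N/N=c1/scc(-c2ccc(Cl)cc2)n1-c1ccccc1` gives 52.4% and compound 3 `Cn1cnnc1SCC(=O)N/N=c1/scc(-c2ccc(C#N)cc2)n1-c1ccccc1` gives 52.6%. Compound 3 stands at the highest of the three numbers; compound 2 lies within the scatter of it, compound 1 beyond. For the measured compounds named here, the only step between compounds that differ in one place is a number 24.8 percentage points higher from compound 1 to compound 3 (beyond the scatter).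

Compound 4 `N#Cc1ccc(-c2cs/c(=N/NC(=O)CSc3nnnn3-c3ccccc3)n2-c2ccccc2)cc1` is not yet measured. It differs from compound 3 by 1-phenyl-1H-tetrazol-5-yl in place of 4-methyl-4H-1,2,4-triazol-3-yl on a sulfur. Going by the values given here, no measured step covers this change on its own: compound 2 carries the 1-phenyl-1H-tetrazol-5-yl group on the sulfur, but it also differs from compound 3 on the aromatic carbon, so only its value and that of compound 3 can be set side by side, and those two numbers lie within the scatter of each other. The change in compound 4 is therefore expected to bring no step beyond the scatter in this assay, so the expected step is a number 0.6 percentage points lower from compound 3 to compound 4 (within the scatter). Compound 4 is thus expected to give about 52% in this assay, within a range from 38% to 66%.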

Compound 4, a percentage reported as activity, at one concentration (the size of the read-out at that concentration, not a potency): 54%
Compound 4: the middle estimate sits 2 percentage points below what was measured; measured number inside the range.
By their numbers in this assay, from the lowest: compound 1; then compounds 2, 3 and 4 (each within the scatter of the next).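

With cyano held on the aromatic carbon, the change on the sulfur now has a step of its own: 1-phenyl-1H-tetrazol-5-yl in place of 4-methyl-4H-1,2,4-triazol-3-yl gives a number 1.4 percentage points higher from compound 3 to compound 4 (within the scatter) in this assay, so the larger group, with its added six-membered aromatic ring, brings no step beyond the scatter. With 1-phenyl-1H-tetrazol-5-yl held on the sulfur, cyano in place of chloro gives a number 1.6 percentage points higher from compound 2 to compound 4 (within the scatter), so these two groups on the aromatic carbon are not told apart in this pair. Nothing measured here gives a reason for either result.

The compounds shown leave open whether methyl on the aromatic carbon keeps its lower number with 1-phenyl-1H-tetrazol-5-yl on the sulfur. From the compounds shown here alone, how an amine or a carboxylic acid on the aromatic carbon, or a longer alkyl chain on the sulfur, would read also remains open.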